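This account rests on a few compounds, and the source may have more. Where it says the series, first, only, none or still open, it means among the compounds named here.

Going by the values given here, compound 1 `NC/C(=C\F)COc1ccccc1` is one of two compounds measured in an assay on isolated protein for inhibition of Amine oxidase [flavin-containing] A (Homo sapiens); on this read-out higher numbers stand for weaker inhibition and lower numbers for stronger inhibition. In this assay, among the compounds with values here, compound 1 gives 4000 nM, the highest of the two numbers; its only neighbour is compound 2 `Cc1ccccc1OC/C(=C/F)CN`, which gives 160 nM. Within the data shown here, the one measured step, a 25-fold lower number from compound 1 to compound 2 (1.40 log units; beyond the scatter), comes from putting a methyl in place of hydrogen on an aromatic carbon, and it says nothing about the double bond.

Compound 3 `NCC(=CF)COc1ccccc1` differs from compound 1 in a different way: the two compounds have the same atoms and bonds; at least one stereo element is drawn with a configuration in one of them and without one in the other: 1 of 1 stereo elements differ; a double bond is drawn E in compound 1 and without a configuration in compound 3. No atom enters or leaves; only the way the double bond is drawn changes, so compound 3 may be the same substance as compound 1 or a sample that holds both geometric forms. Among the measured compounds shown here, no measured step bears on this change, and the other geometric form has not been measured on its own.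

The expected step is therefore none beyond the scatter, no change at the digits printed from compound 1 to compound 3 (within the scatter), with the range widened towards weaker inhibition in case the other geometric form is present. Compound 3 is estimated at 4000 nM, between 2000 nM and 12000 nM.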

Compound 3, half-maximal inhibitory concentration: 2500 nM
Estimate against measurement, compound 3: 1.6-fold (0.20 log units) above, within the range that was stated.
By their numbers in this assay, from the lowest: compound 2; then compounds 3 and 1 (each within the scatter of the next).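

Leaving the double bond without a drawn configuration gives a 1.6-fold lower number from compound 1 to compound 3 (0.20 log units; within the scatter), so this is the first change here whose step stays within the scatter, unlike the methyl step, a 25-fold lower number from compound 1 to compound 2 (1.40 log units; beyond the scatter). In this assay, compound 1 and compound 3 can therefore be read as one level, and for this pair the way the double bond is drawn does not show up as a real difference in the numbers. The comparison rests on a single distinction, a difference in drawing rather than in atoms or bonds: the fact that one of compounds 1 and 3 is drawn with a defined configuration and the other without, at the place where they differ

Compound 3 as drawn does not tell whether its sample holds a single geometric form or a mixture of both, so the inhibition of the form opposite to that of compound 1, taken alone on the same core, remains an open question. Also open, going by these compounds, is how the methyl step compares with other groups in place of that aromatic hydrogen, such as a chlorine atom or a methoxy group, and whether a secondary amine could stand in place of the primary amine.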